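Furan-2-yl replacing furan-3-yl on a shared nucleoside core

A few compounds are considered here, and "the series" means these few. Any claim that something is new, unique, unknown or untested is made for them only; others in the source may bear on it.

Compound 3 `Nc1nc(N)c2c(-c3ccoc3)cn([C@@H]3O[C@H](CO)[C@@H](O)[C@H]3O)c2n1` is one of three close analogues tested in a functional assay on HepG2 cells (Homo sapiens) for antiproliferative activity, read by XTT assay, with a stated time of 72 h; a lower number here means a stronger inhibitor, a higher number a weaker inhibitor. In this assay compound 3 gives > 20000 nM, which is a limit of the assay and not a number. Compound 1 `Nc1nc(N)c2c(-c3ccsc3)cn([C@@H]3O[C@H](CO)[C@@H](O)[C@H]3O)c2n1` carries thiophen-3-yl where compound 3 carries furan-3-yl; in this assay compound 1 gives > 20000 nM, again a limit. Compound 2 `COc1nc(N)nc2c1c(-c1ccco1)cn2[C@@H]1O[C@H](CO)[C@@H](O)[C@H]1O` differs elsewhere on the core; in this assay compound 2 gives > 20000 nM, also a limit. The step that the two limits leave unreadable from compound 1 to compound 3 therefore cannot be sized, and compound 3 stands together with both neighbours at the limit of > 20000 nM in this assay, at which 3 of the 3 values shown sit.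

Compound 4 `Nc1nc(N)c2c(-c3ccco3)cn([C@@H]3O[C@H](CO)[C@@H](O)[C@H]3O)c2n1` differs from compound 3 by furan-2-yl in place of furan-3-yl on an aromatic carbon. Among the compounds with values here, no measured pair resolves a move of the oxygen within the five-membered aromatic ring, and the one step at this aromatic carbon, a step that the two limits leave unreadable from compound 1 to compound 3, is itself unreadable between the two limits. With every value in this assay sitting at the limit, neither a direction nor a size can be read for this change. The expected step that the limit leaves unreadable from compound 3 to compound 4 is therefore taken to lie within the scatter. Compound 4 is expected to give 30000 nM, with a range from 8000 nM to 100000 nM, and most likely to be reported again only as a limit.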

Compound 4, half-maximal inhibitory concentration: > 20000 nM
Compound 4 ended at the assay's limit (the forecaster's own chance of this, stated with the estimate: 85%); the middle value does not contradict the limit.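

Within the data shown here, compound 4 ends at a limit and not at a number, so its steps from compound 1, compound 2 and compound 3 cannot be read, and no new step emerges: the limit of > 20000 nM in this assay, at which 4 of the 4 values shown sit. The compounds shown leave open whether furan-2-yl, furan-3-yl, thiophen-3-yl, or amino in place of methoxy, makes any difference to antiproliferative activity.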